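Side-chain heterocycle swap on the monochlorophenyl analogue

The source may report more compounds than this note shows. Statements on the series, on what has been measured and on what is new or still open speak of the compounds shown alone.

Compound 1 `CCO/C(O)=C1\C(COCCn2nncc2C(N)=O)=NC(C)=C(C(=O)OC)C1c1ccccc1Cl` gives 100 nM in a functional assay (aorta) with Rattus norvegicus as the target (on this read-out lower numbers stand for stronger inhibition and higher numbers for weaker inhibition), the highest of the three numbers in hand. Compound 2 `CCO/C(O)=C1\C(COCCn2cc(C(N)=O)nn2)=NC(C)=C(C(=O)OC)C1c1cccc(Cl)c1Cl` gives 3.16 nM and compound 3 `CCO/C(O)=C1\C(COCCN2CC(=O)N(C)C2=O)=NC(C)=C(C(=O)OC)C1c1cccc(Cl)c1Cl` gives 5.01 nM; both carry a second chlorine on the phenyl ring and differ from compound 1 in more than one place, so their values are only compared, not read as single steps. Going by the values given here, the one step between measured compounds exchanges the side-chain heterocycle and gives a 1.6-fold higher number from compound 2 to compound 3 (0.20 log units; within the scatter). Compound 4 `CCO/C(O)=C1\C(COCCn2ccnc2C)=NC(C)=C(C(=O)OC)C1c1ccccc1Cl` differs from compound 1 by 2-methyl-1H-imidazol-1-yl in place of 5-carbamoyl-1H-1,2,3-triazol-1-yl on a saturated chain carbon, two bonds along the chain from an oxygen on a saturated carbon. This is again a side-chain heterocycle exchange, and given a 1.6-fold higher number from compound 2 to compound 3 (0.20 log units; within the scatter) the expected step is no change at the digits printed from compound 1 to compound 4 (within the scatter), none beyond the scatter. Compound 4 is therefore estimated at 100 nM, in the range 30 nM to 320 nM.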

Compound 4, half-maximal inhibitory concentration: 2.51 nM
Estimate against measurement, compound 4: 40-fold (1.60 log units) above; the measured number lies below the stated range.
By their numbers in this assay, from the lowest: compounds 4, 2 and 3 (each within the scatter of the next); then compound 1.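

On the monochlorophenyl analogue, this position is sensitive to the heterocycle: 2-methyl-1H-imidazol-1-yl in place of 5-carbamoyl-1H-1,2,3-triazol-1-yl gives a 40-fold lower number from compound 1 to compound 4 (1.60 log units; beyond the scatter) in this assay. A side-chain heterocycle exchange at this place therefore need not stay within the scatter, and the step for one pair of groups does not carry over to another. Nothing available bears on the origin of this step.

Still open, as far as these compounds go, is how much of the step belongs to the ring and how much to the carbamoyl group. Also open, from the compounds shown here alone, is what an open-chain amine or a carboxylic acid would give at this place.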